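The source may report more compounds than this note shows. Statements on the series, on what has been measured and on what is new or still open speak of the compounds shown alone.

Of the compounds shown here, three have been measured in a functional assay, with a stated time of 20 min; on this read-out higher numbers stand for weaker inhibition and lower numbers for stronger inhibition. Compound 1 `Cn1c(NN)nc(-c2cccc(O)c2O)c(C#N)c1=O` gives 34 ug/mL in this assay. Compound 2 `Cn1c(NN)nc(-c2ccc(Cl)cc2)c(C#N)c1=O` gives 44 ug/mL, and compound 3 `CCOC(=O)c1cnn(-c2nc(-c3ccc(OC)cc3)c(C#N)c(=O)n2C)c1N` gives 59 ug/mL. Going by the values given here, compound 1 has the lowest of the three numbers, but the other two lie within the scatter of it, so the three cannot be ranked against one another on this assay, and no compound can be called the most or least potent.

Compound 4 `Cn1c(NN)nc(-c2ccccc2O)c(C#N)c1=O` has not yet been measured. It differs from compound 1 by a single change: hydrogen in place of hydroxy on an aromatic carbon. The hydroxy group that is lost sits on the aromatic ring of carbon only, ortho to the remaining hydroxy group and meta to the large group. Among the compounds with values here, no pair of measured compounds shows this kind of step, so its size is not known from the data. Since compounds 1, 2 and 3 carry different substituents on that ring and still fall within the scatter of each other, the step from compound 1 to compound 4 is expected to be small, with no clear direction beyond the scatter, which is what a 1.2-fold higher number from compound 1 to compound 4 (0.07 log units; within the scatter) expresses. Compound 4 is therefore estimated to give about 40 ug/mL in this assay, within a range from 20 ug/mL to 80 ug/mL.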

Compound 4, half-maximal inhibitory concentration: 38 ug/mL
Beside the measured number, compound 4's estimate is 1.1-fold (0.02 log units) above it, and the stated range covers the measured number.
By their numbers in this assay, from the lowest: compounds 1, 4, 2 and 3 (each within the scatter of the next).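

In this assay, going by these compounds alone, the exchange of hydroxy for hydrogen on an aromatic carbon gives the first step between two measured compounds that differ in one place, and it reads a 1.1-fold higher number from compound 1 to compound 4 (0.05 log units; within the scatter). The earlier compounds shown here differed in more than one place, so they could not isolate any single group, whereas this step isolates the hydroxy group ortho to a hydroxy group and meta to a large group, and it shows that this exchange leaves no difference this read-out can separate from the scatter. Nothing measured here bears on why the step has this size.

The compounds shown leave open whether a methoxy group, an amine, a fluorine atom or a carboxylic acid at this same place would give a number beyond the scatter, or whether any group there would move the read-out at all. They also leave open what happens when the remaining hydroxy group is replaced by hydrogen, and whether the step would read the same with another group in place of the large group.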